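Hydroxamate series: solubility estimate for compound 3

A few compounds are considered here, and "the series" means these few. Any claim that something is new, unique, unknown or untested is made for them only; others in the source may bear on it.

Among the measured compounds shown here, compound 2 `CC(NC(=O)c1ccc(C#Cc2ccccc2)cc1)C(=O)NO` is compared here with compound 1 `O=C(N[C@@H](CO)C(=O)NO)c1ccc(C#Cc2ccccc2)cc1`, the only other member measured. In a physicochemical assay for solubility (a higher number here means a more soluble compound, a lower number a less soluble compound), compound 1 gives 28000 nM, and compound 2 gives 29000 nM. For the measured compounds named here, the single step measured, a 1.0-fold higher number from compound 1 to compound 2 (0.02 log units; within the scatter), shows the two numbers lying within the scatter of each other, so no order between compound 1 and compound 2 can be read from them.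

Compound 3 `O=C(N[C@H](CO)C(=O)NO)c1ccc(C#Cc2ccccc2)cc1` is not yet measured. Relative to compound 2 the change is a group of 7 heavy atoms (3 carbon, 1 nitrogen, 3 oxygen; no ring) in place of a group of 6 heavy atoms (3 carbon, 1 nitrogen, 2 oxygen; no ring), on an amide-type nitrogen. Going by the values given here, this is the reverse of the only measured step, which exchanged the same two groups on the same amide-type nitrogen; that step, a 1.0-fold higher number from compound 1 to compound 2 (0.02 log units; within the scatter), was within the scatter. The same exchange in the other direction is therefore expected to leave the number where it is, the expected step being a 1.0-fold lower number from compound 2 to compound 3 (0.02 log units; within the scatter). For compound 3 the estimate is 28000 nM, with a range of 14000 nM to 56000 nM.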

Compound 3, solubility: 36000 nM
Compound 3: the middle estimate sits 1.3-fold (0.11 log units) below what was measured; the range from low to high includes it.
By their numbers in this assay, from the lowest: compounds 1, 2 and 3 (each within the scatter of the next).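

In this assay, the exchange on the amide-type nitrogen now has a second reading, a 1.2-fold higher number from compound 2 to compound 3 (0.09 log units; within the scatter), and this step again lies within the scatter. Among the compounds shown here, the new pair adds a comparison that the earlier compounds did not offer, a 1.3-fold higher number from compound 1 to compound 3 (0.11 log units; within the scatter), and it shows that the two drawn configurations at the saturated chain carbon cannot be ordered in this assay. This reading concerns the stereocentre alone, and it rests on one fact: the fact that compounds 1 and 3 differ only in the configuration as drawn

The compounds shown leave open whether another group on the amide-type nitrogen, such as one carrying an amine, a carboxylic acid or a longer chain, would give a step beyond the scatter. They also leave open whether configuration would remain unreadable in such a group.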